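Trading a Brominated Ring for a Plain One

The compounds below may be only part of what the source reports. "The series", "measured", "known", "first", "only" and "open" are said of these compounds alone.

Compound 1 `COc1ccc(-c2cc3ccccc3nc2C=O)cc1` and compound 2 `COc1ccc(-c2cc3ccccc3nc2/C=C/C(=O)c2ccc(Br)s2)cc1` share one core, which compound 2 extends with a longer chain ending in a second ring. In a functional assay on NCI-H460 cells (Homo sapiens) for antiproliferative activity, read by XTT assay, with a stated time of 72 h (on this read-out higher numbers stand for weaker inhibition and lower numbers for stronger inhibition), compound 1 reaches only a limit, > 10000 nM. In this assay, going by the values given here, compound 2 gives 5170 nM, the only full number here. The other value shown is a limit: the limit of > 10000 nM in this assay, at which 1 of the 2 values shown sits. Compound 3 `COc1ccc(-c2cc3ccccc3nc2/C=C/C(=O)c2ccsc2)cc1` differs from compound 2 by thiophen-3-yl in place of 5-bromothiophen-2-yl on a carbonyl carbon. Among the compounds with values here, no measured step covers such a change, so the expected step of a 1.5-fold higher number from compound 2 to compound 3 (0.19 log units; within the scatter) is small, leaning toward weaker inhibition. Compound 3 is estimated at 8000 nM, within 3000 nM to 25000 nM.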

Compound 3, half-maximal inhibitory concentration: 7080 nM
Compound 3: middle estimate off by 1.1-fold (0.05 log units), on the high side, within the range that was stated.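

In this assay, thiophen-3-yl in place of 5-bromothiophen-2-yl on the carbonyl carbon gives a 1.4-fold higher number from compound 2 to compound 3 (0.14 log units; within the scatter), so here the plain ring and the brominated ring cannot be told apart. Replacing formyl with 2-((thiophen-3-yl)carbonyl)ethenyl gives an at least 1.4-fold lower number from compound 1 to compound 3 (0.14 log units; that floor lies within the scatter), a floor that does not separate the two compounds. Compound 1 has a limit rather than a number: the limit of > 10000 nM in this assay, at which 1 of the 3 values shown sits.

This swap removes the bromine and also changes where the ring is attached, so the two changes cannot be read separately. Plain thiophen-2-yl would part them, and a ring carrying an amine or a carboxylic acid remains open.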